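Removing the fluorines: phenyl in place of 2,6-difluorophenyl

The source may report more compounds than this note shows. Statements on the series, on what has been measured and on what is new or still open speak of the compounds shown alone.

Compound 1 `CC(C)(C)n1ncc(OCc2nnc(-c3cccs3)o2)c(Cl)c1=O`: > 300 ug/mL
Compound 2 `CC(C)(C)n1ncc(OCc2nnc(-c3c(F)cccc3F)o2)c(Cl)c1=O`: 45.4 ug/mL

Of the compounds shown here, two of the shared core have been tested in a functional assay on the whole organism for inhibition, with Mythimna separata as the target, with a stated time of 5 days; on this read-out lower numbers stand for an effect already at smaller amounts and higher numbers for an effect only at larger amounts of compound. For compound 1 the result is only a limit of the assay, > 300 ug/mL. Going by the values given here, compound 2 gives the single actual number, 45.4 ug/mL, and so it stands as the only measured figure here.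

Compound 3 `CC(C)(C)n1ncc(OCc2nnc(-c3ccccc3)o2)c(Cl)c1=O` differs from compound 2 by phenyl in place of 2,6-difluorophenyl on an aromatic carbon. Among the compounds with values here, no measured step covers this exact change. Within the data shown here, the one step known, an at least 6.6-fold lower number from compound 1 to compound 2 (0.82 log units; beyond the scatter), concerns a different aryl group and is anchored on a limit, (the limit of > 300 ug/mL in this assay, at which 1 of the 2 values shown sits), so it sets no firm size for the present change. Compound 3 is therefore expected to lie near compound 2, with a step of a 2.0-fold higher number from compound 2 to compound 3 (0.30 log units; within the scatter). The estimate for compound 3 in this assay is 90 ug/mL, with a range from 30 ug/mL to 300 ug/mL.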

Compound 3, half-maximal effective concentration: 12.2 ug/mL
Beside the measured number, compound 3's estimate is 7.4-fold (0.87 log units) above it, outside the stated range (below it).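

In this assay, the plain phenyl on this aromatic carbon does better than the 2,6-difluorophenyl, with a 3.7-fold lower number from compound 2 to compound 3 (0.57 log units; beyond the scatter), so neither fluorine is required for the effect, and compound 3 has the lowest number of the three compounds shown. Phenyl in place of thiophen-2-yl gives an at least 24-fold lower number from compound 1 to compound 3 (1.39 log units; beyond the scatter). That step is anchored on the limit of compound 1: the limit of > 300 ug/mL in this assay, at which 1 of the 3 values shown sits.

On these data alone, it remains open whether a single fluorine, or a chlorine, a methyl or a methoxy group on the phenyl, would lower the number further or raise it. The compounds shown also do not tell why removing the two fluorines lowers the number, or whether the same change would hold on a core with another group in place of the tert-butyl.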